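Swapping nitro for trifluoromethyl on compound 3

The source may report more compounds than this note shows. Statements on the series, on what has been measured and on what is new or still open speak of the compounds shown alone.

Measured so far in a functional assay on HeLa cells (Homo sapiens) for inhibition, read by MTT assay, with a stated time of 72 h; on this read-out higher numbers stand for weaker inhibition and lower numbers for stronger inhibition:
- Compound 1 `COc1cc(O)c(CC=C(C)C)c(O)c1C(=O)/C=C/c1ccc(C(F)(F)F)cc1` gives 6800 nM
- Compound 2 `COc1ccc(/C=C/C(=O)c2c(O)cc(O)cc2OC)cc1` gives 47700 nM
- Compound 3 `COc1cc(O)cc(O)c1C(=O)/C=C/c1ccc([N+](=O)[O-])cc1` gives > 50000 nM as a limit, not a number

Compound 3 stands at the limit of > 50000 nM in this assay, at which 1 of the 3 values shown sits, and so has no exact value. Compound 4 `COc1cc(O)cc(O)c1C(=O)/C=C/c1ccc(C(F)(F)F)cc1` carries trifluoromethyl in place of nitro on an aromatic carbon. Going by the values given here, the one measured step at this place, nitro in place of methoxy, is an at least 1.0-fold higher number from compound 2 to compound 3 (0.02 log units; that floor lies within the scatter) and sets no clear size. Compound 1 also carries trifluoromethyl and gives 6800 nM, but its core differs from that of compound 4, so it is only a loose guide. The expected change in this assay is an at least 1.6-fold lower number from compound 3 to compound 4 (0.22 log units; that floor lies within the scatter) as a modest move toward stronger inhibition. The estimate for compound 4 is 30000 nM, with 12000 nM to 60000 nM as the expected range.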

Compound 4, half-maximal inhibitory concentration: 9500 nM
Compound 4: middle estimate off by 3.2-fold (0.50 log units), on the high side; measured number outside the range, below it.
By their numbers in this assay, from the lowest: compounds 1 and 4 (each within the scatter of the next); then compound 2. At a limit, above all of these: compound 3.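

Trifluoromethyl at this place stands clearly apart from nitro (an at least 5.2-fold lower number from compound 3 to compound 4 (0.72 log units; beyond the scatter)) and from methoxy (a 5.0-fold lower number from compound 2 to compound 4 (0.70 log units; beyond the scatter)) in this assay and so this position responds to the group it carries. Hydrogen in place of 3-methylbut-2-en-1-yl makes no clear difference (a 1.4-fold higher number from compound 1 to compound 4 (0.15 log units; within the scatter)) so that chain is not needed for this level of inhibition. The step from nitro is only a floor, with compound 3 at a limit: the limit of > 50000 nM in this assay, at which 1 of the 4 values shown sits.

From the compounds shown here alone, whether an amine, a carboxylic acid or a single chlorine at this place would match trifluoromethyl stays open. So does whether a longer chain on the shared core would change the number.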